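Cytotoxicity notes: carboxy to hydroxycarbamoyl on the shared core

The source may hold more compounds than are shown below. What is called first, only, known or untested is meant among the compounds shown, and "the series" means these compounds.

Measured compounds, read in a functional assay on SMMC-7721 cells (Homo sapiens) for cytotoxicity, read by MTT assay, with a stated time of 48 h; on this read-out higher numbers stand for weaker inhibition and lower numbers for stronger inhibition:
compound 1 `O=C(N[C@H]1CC[C@]2(CC1)OO[C@]1(O2)C2CC3CC(C2)CC1C3)c1ccc(O)c(O)c1`, at a limit: > 50000 nM
compound 2 `Oc1ccc(N[C@H]2CC[C@]3(CC2)OO[C@]2(O3)C3CC4CC(C3)CC2C4)c2cccnc12`: 7300 nM
compound 3 `O=C(O)[C@H]1CC[C@@]2(CC1)OC[C@]1(OO2)C2CC3CC(C2)CC1C3`, at a limit: > 100000 nM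

Compound 3 sits at the upper limit of this assay and gives no number. Compound 1 also sits at a limit, as the line the limit of > 50000 nM in this assay, at which 1 of the 3 values shown sits, records. Compound 2 is the only one of the three with a measured value, and compound 3 stands at the line (the limit of > 100000 nM in this assay, at which 1 of the 3 values shown sits), the top of what this assay reports.

Compound 4 `O=C(NO)[C@H]1CC[C@@]2(CC1)OC[C@]1(OO2)C2CC3CC(C2)CC1C3` is not yet measured. It differs from compound 3 in one place: hydroxyamino in place of hydroxy on a carbonyl carbon. No step between measured compounds is shown, so nothing in the series tells how such a change moves the read-out. The step of an at least 1.6-fold lower number from compound 3 to compound 4 (0.22 log units; that floor lies within the scatter) is the expected one, and it is an estimate of a small shift or none beyond the scatter, with the outcome quite possibly again a limit rather than a number. For compound 4 the expected value is 60000 nM, with a range from 15000 nM to 200000 nM.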

Compound 4, half-maximal inhibitory concentration: > 50000 nM
Compound 4 was reported as a limit; the forecaster's own chance of this, stated with the estimate: 55%; the middle value does not contradict the limit.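

In this assay compound 4 gives > 50000 nM, a limit and not a number. Compound 3 gives > 100000 nM, also a limit. Going by these compounds alone, no step from compound 3 to compound 4 can be read from these two limits. The compounds shown leave open whether hydroxyamino in place of hydroxy on a carbonyl carbon moves the read-out at all.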